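Side-chain swap on a shared core: from amide to sec-butyl

The source may report more compounds than this note shows. Statements on the series, on what has been measured and on what is new or still open speak of the compounds shown alone.

Of the compounds shown here, three sharing one core have been tested in a functional assay on the whole organism (Tail, strain ICR) with Mus musculus as the target, in the tail flick test, with a stated time of 30 min, at a dose of 25 umol/kg by the oral route; a lower number here means a weaker effect, a higher number a stronger effect of the compound at the dose given. Compound 2 `NC(=O)CC[C@H](NC(=O)CN(c1nc(Cl)nc2[nH]cnc12)C1CC1)C(=O)O` gives 33.1%, the top number of the three, yet its gaps to both others lie within the scatter: compound 3 `NC(=O)CC[C@H](NC(=O)CN(c1nc(Cl)nc2[nH]cnc12)C1CC1)C(=O)OCc1ccccc1` gives 30.8%, a step of a number 2.3 percentage points lower from compound 2 to compound 3 (within the scatter), and compound 1 `N=C(N)NCCC[C@H](NC(=O)CN(c1nc(Cl)nc2[nH]cnc12)C1CC1)C(=O)OCc1ccccc1` gives 23.2%. Among the measured compounds shown here, the one side-chain step already seen, a number 7.6 percentage points higher from compound 1 to compound 3 (within the scatter), also stayed within the scatter.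

Compound 4 `CC[C@H](C)[C@H](NC(=O)CN(c1nc(Cl)nc2[nH]cnc12)C1CC1)C(=O)O` is the next step from compound 2, by sec-butyl in place of 2-carbamoylethyl on a saturated chain carbon bound to an amide-type nitrogen and a carbonyl carbon. Since the earlier side-chain change from compound 1 to compound 3 moved nothing beyond the scatter, no step beyond the scatter is expected here either, so that a number 3.1 percentage points lower from compound 2 to compound 4 (within the scatter) is the estimated change. Compound 4 is therefore expected to give about 30%, between 18% and 42%.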

Compound 4, a percentage reported as activity, at one dose (the size of the read-out at that dose, not a potency): 30.3%
Compound 4: the middle estimate sits 0.3 percentage points below what was measured, and the stated range covers the measured number.
By their numbers in this assay, from the lowest: compounds 1, 4, 3 and 2 (each within the scatter of the next).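

In this assay, the exchange on a saturated chain carbon bound to an amide-type nitrogen and a carbonyl carbon gives a number 2.8 percentage points lower from compound 2 to compound 4 (within the scatter), now with the free carboxylic acid kept rather than the benzyl ester of the earlier side-chain pair. Sec-butyl, with 0 hydrogen-bond donors and 0 hydrogen-bond acceptors, thus replaces 2-carbamoylethyl without a step beyond the scatter. No measurement at hand explains this result.

On these data alone, whether an amine or a phenyl ring on this side chain, or a longer chain, would step beyond the scatter remains open.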